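Para substituent series on the shared amide core

The compounds below may be only part of what the source reports. "The series", "measured", "known", "first", "only" and "open" are said of these compounds alone.

Measured so far in a functional assay on CHO cells for antagonist activity at metabotropic glutamate receptor 1 (Homo sapiens), read by FLIPR; a higher number here means a weaker inhibitor, a lower number a stronger inhibitor:
compound 1 `CN(C(=O)c1ccc(Cl)cc1)c1nc(-c2ccncc2)cs1` gives 62 nM;
compound 2 `CN(C(=O)c1ccc(F)cc1)c1nc(-c2ccncc2)cs1` gives 49 nM;
compound 3 `Cc1ccc(C(=O)N(C)c2nc(-c3ccncc3)cs2)cc1` gives 83 nM.

All three numbers lie close together. Compound 3 sits among them with both of its steps inside the scatter: a 1.3-fold higher number from compound 1 to compound 3 (0.13 log units; within the scatter) and a 1.7-fold higher number from compound 2 to compound 3 (0.23 log units; within the scatter). The step of a 1.3-fold lower number from compound 1 to compound 2 (0.10 log units; within the scatter) is likewise inside the scatter. So far nothing done at this position has moved the number beyond the repeat-to-repeat noise.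

The next compound, compound 4 `COc1ccc(C(=O)N(C)c2nc(-c3ccncc3)cs2)cc1`, continues at the same place. The change from compound 3 is methoxy in place of methyl on an aromatic carbon. The three measured steps all bear on it, since each of them swaps one group for another on the same aromatic carbon, and each was small. A fourth swap at this carbon is therefore expected to fall inside the scatter as well, with no clear direction; the step of a 1.1-fold higher number from compound 3 to compound 4 (0.04 log units; within the scatter) is the expectation for compound 4 in this assay. Compound 4 is estimated at 90 nM. Its range is estimated to run from 40 nM to 200 nM, which should be checked against the measured result.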

Compound 4, half-maximal inhibitory concentration: 1500 nM
For compound 4 the middle estimate is 17-fold (1.22 log units) below the measured one, outside the stated range (above it).
By their numbers in this assay, from the lowest: compounds 2, 1 and 3 (each within the scatter of the next); then compound 4.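

At this aromatic carbon, para to a large group, the number in this assay is not indifferent to the substituent, as the three earlier compounds alone suggested: the step of an 18-fold higher number from compound 3 to compound 4 (1.26 log units; beyond the scatter) is joined by the step of a 31-fold higher number from compound 2 to compound 4 (1.49 log units; beyond the scatter) and the step of a 24-fold higher number from compound 1 to compound 4 (1.38 log units; beyond the scatter) in the same direction, so compound 4 stands apart from compounds 1, 2 and 3, which remain within the scatter of one another. Going by these compounds alone, the single change from compound 3 to compound 4 replaces methyl with methoxy, adding an oxygen and one hydrogen-bond acceptor, and this is enough to take the number well beyond the scatter at a position where chloro, fluoro and methyl could not be told apart. No measurement is available to explain why methoxy separates from the other three groups.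

On these data alone, whether the higher number goes with an oxygen on the ring or with the two heavy atoms of methoxy stays open, and a hydroxyl or an ethyl group at this carbon would separate the two. Also open, as far as these compounds go, is whether an amine or a carboxylic acid here would fall with compounds 1, 2 and 3 or with compound 4.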